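The source may report more compounds than this note shows. Statements on the series, on what has been measured and on what is new or still open speak of the compounds shown alone.

Compound 1: `Cc1ccc2c(c1)C(C)(C)[C@H]1COc3ccc4c(=O)c(C)c(C)oc4c3[C@H]1N2`, 94300 nM
Compound 2: `Cc1oc2c3c(ccc2c(=O)c1-c1ccccc1)OC[C@H]1[C@@H]3Nc2ccccc2C1(C)C`, > 100000 nM

Both compounds were tested in a functional assay on MCF7 cells (Homo sapiens) for antiproliferative activity, read by MTT assay; on this read-out lower numbers stand for stronger inhibition and higher numbers for weaker inhibition. Compound 1 gives 94300 nM in this assay. For compound 2 the result is only a limit of the assay, > 100000 nM, so no number is known for it. Among the two values shown, compound 2 therefore stands at the limit of > 100000 nM in this assay, at which 1 of the 2 values shown sits.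

Compound 3, `Cc1ccc2c(c1)C(C)(C)[C@H]1COc3ccc4c(=O)c(-c5ccccc5)c(C)oc4c3[C@H]1N2`, is still to be measured in this assay. It differs from compound 2 by methyl in place of hydrogen on an aromatic carbon. Within the data shown here, no step between measured compounds carries this same change, so nothing in the data fixes its size. Compound 1, which also carries a methyl at that position, gives 94300 nM, a weak result. The step of a number no higher from compound 2 to compound 3 (the limit leaves the size open) is expected to stay within the scatter. Compound 3 is expected to give about 100000 nM, in a range from 40000 nM to 300000 nM, with a real chance that only a limit is reported.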

Compound 3, half-maximal inhibitory concentration: 10000 nM
Compound 3: middle estimate off by 10-fold (1.00 log units), on the high side; the measured number lies below the stated range.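

Methyl in place of hydrogen on this aromatic carbon is not a silent change in this assay: it gives an at least 10-fold lower number from compound 2 to compound 3 (1.00 log units; beyond the scatter). From the compounds shown here alone, compound 2 stands at a limit of the assay rather than at a number, so the true size of that step remains open: the limit of > 100000 nM in this assay, at which 1 of the 3 values shown sits. The phenyl counts as well, since phenyl in place of methyl on an aromatic carbon gives a 9.4-fold lower number from compound 1 to compound 3 (0.97 log units; beyond the scatter), so among these three compounds, the lower number appears only where the methyl and the phenyl are present together.

The compounds shown do not tell whether an ethyl group, a methoxy group or a chlorine atom on that same aromatic carbon would lower the number further. They also leave open what a phenyl ring bearing an amine or a carboxylic acid would do, and they give no reason for the gain.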